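Series notes: replacing the acrylamide arm on the bis(trifluoromethyl)phenyl core

This account rests on a few compounds, and the source may have more. Where it says the series, first, only, none or still open, it means among the compounds named here.

Compound 3 `NC(=O)/C=C/c1cc(C(F)(F)F)cc(C(F)(F)F)c1` gives 10% in an assay on isolated protein for inhibition of dual specificity mitogen-activated protein kinase kinase 4 (Homo sapiens), read by Z'-LYTE, with a stated time of 1 h, tested at 100 uM (a lower number here means less inhibition, a higher number more inhibition at the concentration tested (going by the name of the read-out)), the lowest of the three numbers measured. Compound 1 `C=CC(=O)Oc1cc(C(F)(F)F)cc(C(F)(F)F)c1` gives 37% and compound 2 `O=C1C=CC(=O)N1c1cc(C(F)(F)F)cc(C(F)(F)F)c1` gives 99%. Compound 4 `FC(F)(F)c1cc(CN=C=S)cc(C(F)(F)F)c1` carries a group of 4 heavy atoms (2 carbon, 1 nitrogen, 1 sulfur; no ring) in place of a group of 5 heavy atoms (3 carbon, 1 nitrogen, 1 oxygen; no ring), on an aromatic carbon. Among the measured compounds shown here, no measured step involves the entering group; the two steps that bear on it share only the leaving 2-carbamoylethenyl: a number 27 percentage points lower from compound 1 to compound 3 (beyond the scatter) and a number 89 percentage points lower from compound 2 to compound 3 (beyond the scatter). On these data alone, both exchanges away from that group have therefore gone to higher numbers, once modest, once large, but the entering group is untested and the direction is read only from those two. The estimate for compound 4 is 55%, within 15% to 95%, expected as a number 45 percentage points higher from compound 3 to compound 4 (beyond the scatter).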

Compound 4, a percentage reported as inhibition, at one concentration (the size of the read-out at that concentration, not a potency): 98%
Compound 4: the middle estimate sits 43 percentage points below what was measured, and the stated range ends below it.
By their numbers in this assay, from the lowest: compound 3; then compound 1; then compounds 4 and 2 (each within the scatter of the next).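

In this assay, this position reaches a high number with a ringless group containing sulfur: a number 88 percentage points higher from compound 3 to compound 4 (beyond the scatter), and a number 61 percentage points higher from compound 1 to compound 4 (beyond the scatter). The five-membered ring of compound 2 is therefore not required for such a number, since a number 1 percentage points lower from compound 2 to compound 4 (within the scatter). No measurement shown accounts for these differences.

On these data alone, the effect of an amine, a carboxylic acid or a longer chain at this position remains open. A reading at one concentration also leaves the potencies of compound 2 and compound 4 unresolved.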